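The compounds below may be only part of what the source reports. "The series", "measured", "known", "first", "only" and "open" are said of these compounds alone.

In a functional assay on HCC1937 cells (Homo sapiens) for antiproliferative activity, read by CCK-8 assay, with a stated time of 72 h (on this read-out lower numbers stand for stronger inhibition and higher numbers for weaker inhibition), compound 2 `O=C(Nc1cccc(-c2oc3cc(-c4ccc(F)cc4)ccc3c(=O)c2O)c1)c1cccc(F)c1` gives 6590 nM. Among the compounds with values here, this is the low end of the two numbers so far, yet still within the scatter of compound 1 `Cc1ccc(C(=O)Nc2cccc(-c3oc4cc(-c5ccc(F)cc5)ccc4c(=O)c3O)c2)cc1`, which in this assay gives 7110 nM. Within the data shown here, the one measured step, a 1.1-fold lower number from compound 1 to compound 2 (0.03 log units; within the scatter), also swapped the ring on the carbonyl carbon and stayed within the scatter. Compound 3 `CCc1ccc(C(=O)Nc2cccc(-c3oc4cc(-c5ccc(F)cc5)ccc4c(=O)c3O)c2)cc1` has not yet been measured and differs from compound 2 by 4-ethylphenyl in place of 3-fluorophenyl on a carbonyl carbon. On that basis no step beyond the scatter is expected in this assay. For compound 3 the estimate is 7000 nM, with a range from 3500 nM to 14000 nM, an expected step of a 1.1-fold higher number from compound 2 to compound 3 (0.03 log units; within the scatter).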

Compound 3, half-maximal inhibitory concentration: 13200 nM
Compound 3: middle estimate off by 1.9-fold (0.28 log units), on the low side; the measured number falls inside the stated range.
By their numbers in this assay, from the lowest: compounds 2, 1 and 3 (each within the scatter of the next).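

In this assay the carbonyl carbon now carries a third ring, 4-ethylphenyl, and swapping it in for 3-fluorophenyl gives a 2.0-fold higher number from compound 2 to compound 3 (0.30 log units; within the scatter) on this position. Extending the 4-methylphenyl group to 4-ethylphenyl, a methyl in place of a hydrogen on the chain, gives a 1.9-fold higher number from compound 1 to compound 3 (0.27 log units; within the scatter), so neither change moves the number beyond the usual scatter. Nothing measured here explains these numbers. On these data alone, whether an amine or a carboxylic acid on this ring, or a chain longer than ethyl, would give a step beyond the scatter remains open.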